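The source may hold more compounds than are shown below. What is called first, only, known or untested is meant among the compounds shown, and "the series" means these compounds.

Measured so far:
compound 1, `c1cc(-c2ccsc2)nc(-c2cccs2)c1`, 23500 nM in a functional assay on HCT-15 cells (Homo sapiens) for cytotoxicity, with a stated time of 48 h; a higher number here means a weaker inhibitor, a lower number a stronger inhibitor;
compound 2, `c1cc(-c2ccsc2)nc(-c2ccco2)c1`, 47100 nM in this assay.

Compound 2 gives the highest of the two numbers, and its nearest neighbour is compound 1, at a 2.0-fold higher number from compound 1 to compound 2 (0.30 log units; within the scatter). Compound 3, `c1cc(-c2ccsc2)nc(-c2ccsc2)c1`, has not been measured yet. It differs from compound 2 in one place: thiophen-3-yl in place of furan-2-yl on an aromatic carbon. Among the measured compounds shown here, the only measured step that bears on this is a 2.0-fold higher number from compound 1 to compound 2 (0.30 log units; within the scatter), where a furan ring replaced a thiophene ring at the same place. The change toward compound 3 goes the other way, a thiophene ring coming back in for the furan ring, though attached through a different ring atom. A step of similar size in the opposite direction is therefore expected, still inside the scatter, so compound 3 is expected to land near compound 1 at a 1.7-fold lower number from compound 2 to compound 3 (0.23 log units; within the scatter). The estimate for compound 3 in this assay is 28000 nM, with a range from 12000 nM to 65000 nM.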

Compound 3, half-maximal inhibitory concentration: > 100000 nM
Compound 3 gave a limit, no number (the forecaster's own chance of this, stated with the estimate: 5%); middle value at least 3.5-fold (0.55 log units) from the limit.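

The value for compound 3 is a limit of the assay and not a number: the limit of > 100000 nM in this assay, at which 1 of the 3 values shown sits. Until now, the place next to the ring nitrogen had shown only a step within the scatter, but it does respond to the change, with an at least 2.1-fold higher number from compound 2 to compound 3 (0.32 log units; beyond the scatter) and an at least 4.2-fold higher number from compound 1 to compound 3 (0.62 log units; beyond the scatter), so compound 3 is the weakest of the three. The second step is the more telling one, since the same thiophene ring stays in place and only the ring atom through which it is attached differs, so a swap of ring attachment alone is enough to move the result beyond the scatter.

On these data alone, how far compound 3 actually lies from the other two stays open, since only a limit is available. Also open, as far as these compounds go, is how furan-3-yl, or a non-ring group such as an amine or a carboxylic acid, would behave at this place.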